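Methoxy to bromo on the fused ring of compound 1

The source may report more compounds than this note shows. Statements on the series, on what has been measured and on what is new or still open speak of the compounds shown alone.

Measured so far in a functional assay on MCF7 cells (Homo sapiens) for inhibition, read by MTT assay, with a stated time of 48 h, tested at 7.5 ug/mL; on this read-out lower numbers stand for less inhibition of growth and higher numbers for more inhibition of growth at the one concentration tested:
compound 1, `COc1cccc2c1OCN(c1ccc3oc(-c4ccccc4)cc(=O)c3c1)C2`, 32.5%
compound 2, `O=c1cc(-c2ccccc2)oc2cc(N3COc4c(cccc4[N+](=O)[O-])C3)ccc12`, "not active" (no number reported)
compound 3, `O=c1cc(-c2ccccc2)oc2ccc(N3COc4c(Cl)cc(Cl)cc4C3)cc12`, 32.8%

Compound 1 holds the lower of the two numbers reported in this assay, and compound 3 sits within the scatter of it; compound 2 gave no number at all. Compound 4, `O=c1cc(-c2ccccc2)oc2ccc(N3COc4c(Br)cccc4C3)cc12`, keeps the shared core and differs from compound 1 in one place: bromo in place of methoxy on an aromatic carbon. No change between two measured compounds is available to size this exchange, so the step from compound 1 to compound 4 is expected to be small, a number 1.5 percentage points lower from compound 1 to compound 4 (within the scatter), with no direction beyond the scatter. Compound 4 is accordingly estimated at 31%, within a range of 15% to 45%.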

Compound 4, percent growth inhibition at one concentration: "not active" (no number reported)
The entry for compound 4 holds no number; there is nothing to compare the estimate with.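

In this assay, within the data shown here, compound 4 has no number, so no step from compound 1 to compound 4 can be read. The compounds shown leave open how bromo compares numerically with methoxy at this place on the shared core. No available data explain this result.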